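Hydroxycyclohexyl re-entry with gem-dimethyl on the shared core

The compounds below may be only part of what the source reports. "The series", "measured", "known", "first", "only" and "open" are said of these compounds alone.

Compound 3 `CO[C@H]1CC[C@H](CNc2cc(NCc3cnccc3C(F)(F)F)ncc2C#N)CC1` is the compound of interest in an assay on isolated protein for inhibition of protein kinase C theta type (Homo sapiens), read by TR-FRET, with a stated time of 2 h (a higher number here means a weaker inhibitor, a lower number a stronger inhibitor), where compound 3 gives 330 nM. That is the second highest of the three numbers in hand. Its nearest neighbour is compound 2 `N#Cc1cnc(NCc2cnccc2C(F)(F)F)cc1NC[C@H]1CC[C@@H](O)CC1`, which in this assay gives 58 nM; furthest is compound 1 `N#Cc1cnc(NCc2ccccc2C(F)(F)F)cc1N[C@H]1CC[C@H](O)CC1`, which gives 4000 nM. Going by the values given here, the one single-change step available, a 5.7-fold higher number from compound 2 to compound 3 (0.76 log units; beyond the scatter), shows that replacing the hydroxyl on the ring by a methoxy raised the number by a modest but real amount.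

Compound 4 `CC1(C)C[C@@H](Nc2cc(NCc3cnccc3C(F)(F)F)ncc2C#N)CC[C@@H]1O` differs from compound 3 as 4-hydroxy-3,3-dimethylcyclohexyl in place of (4-methoxycyclohexyl)methyl on a nitrogen on an aromatic ring. The change thus brings the hydroxyl back, as in compound 2, while also removing the methylene and adding two methyls on the ring. Only the hydroxyl part is covered by a measured step: the reverse of a 5.7-fold higher number from compound 2 to compound 3 (0.76 log units; beyond the scatter) argues for a lower number. Compound 1 carries the ring directly on the nitrogen with a hydroxyl, but it also differs in the aromatic ring on the other side, so its value cannot be read as a single step. Among the compounds with values here, the gem-dimethyl has no precedent here.

Compound 4 is therefore expected to move by a 2.2-fold lower number from compound 3 to compound 4 (0.34 log units; beyond the scatter) toward a lower number. The estimate for compound 4 is 150 nM, within 40 nM to 600 nM.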

Compound 4, half-maximal inhibitory concentration: 120 nM
Compound 4: the middle estimate sits 1.3-fold (0.10 log units) above what was measured; low and high end bracket the measured number.
By their numbers in this assay, from the lowest: compound 2; then compound 4; then compound 3; then compound 1.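

In this assay, a hydroxylated ring set directly on the nitrogen on an aromatic ring holds up on the shared core: there is a 2.8-fold lower number from compound 3 to compound 4 (0.44 log units; beyond the scatter), so 4-hydroxy-3,3-dimethylcyclohexyl reads lower than (4-methoxycyclohexyl)methyl at this position. Going by these compounds alone, the same group does not reach the level of (4-hydroxycyclohexyl)methyl, with a 2.1-fold higher number from compound 2 to compound 4 (0.32 log units; beyond the scatter), which leaves compound 2 with the lowest number of the series so far. Each of these steps bundles several changes, the loss of the chain carbon and the two added methyls in both, plus the return of the hydroxyl in the first, and nothing at hand bears on why the number moves.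

From the compounds shown here alone, the share of each change remains open, above all whether the two methyls raise the number, lower it or leave it unchanged on an otherwise identical 4-hydroxycyclohexyl group on this core. Also open, going by these compounds, is how this position responds when a primary amine or a carboxylic acid stands in place of the hydroxyl, or when a longer chain links the ring to the nitrogen.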